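Compound 3: a three-membered ring enters the chain

This account rests on a few compounds, and the source may have more. Where it says the series, first, only, none or still open, it means among the compounds named here.

Measured so far in a functional assay on COR-L23 cells (Homo sapiens) for antiproliferative activity, read by CellTiter-Glo, with a stated time of 4 days; on this read-out higher numbers stand for weaker inhibition and lower numbers for stronger inhibition:
Compound 1 `O=C(CCc1cccnc1)Nc1ccc(CN2C(=O)c3ccccc3C2=O)cc1` gives > 10000 nM as a limit of the assay
Compound 2 `O=C(/C=C/c1cccnc1)Nc1ccc(CN2C(=O)c3ccccc3C2=O)cc1` gives 2000 nM as a true number

Within the data shown here, compound 2 holds the only true number so far, and it therefore serves as the reference for the next change. The reading for compound 1 is only a limit. The next structure is compound 3 `O=C(Nc1ccc(CN2C(=O)c3ccccc3C2=O)cc1)[C@H]1C[C@@H]1c1cccnc1` and its change is a group of 9 heavy atoms (8 carbon, 1 nitrogen; one three-membered non-aromatic ring of carbon only, one six-membered aromatic ring with 1 hetero atom) in place of a group of 8 heavy atoms (7 carbon, 1 nitrogen; one six-membered aromatic ring with 1 hetero atom), on a carbonyl carbon on a carbonyl carbon. The entering group carries a three-membered non-aromatic ring of carbon only and 2 defined stereocentres.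

Among the measured compounds shown here, one measured step bears on this, at the same kind of carbonyl carbon. It is an at least 5.0-fold lower number from compound 1 to compound 2 (0.69 log units; beyond the scatter) and it lies beyond the scatter, so results in this series do respond to a change in this group. That single step cannot fix the size of the next one, so the expectation stays broad. Starting from compound 2 at 2000 nM a modest gain is expected. In this assay the estimated move is a 2.5-fold lower number from compound 2 to compound 3 (0.40 log units; beyond the scatter) toward stronger inhibition. The expected value for compound 3 is 800 nM within an estimated range of 150 nM to 4000 nM overall.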

Compound 3, half-maximal inhibitory concentration: 35 nM
Beside the measured number, compound 3's estimate is 23-fold (1.36 log units) above it; the whole stated range lies above it.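

In this assay, replacing 2-(pyridin-3-yl)ethenyl with the group carrying a three-membered non-aromatic ring of carbon only, on the same carbonyl carbon, gives a 57-fold lower number from compound 2 to compound 3 (1.76 log units; beyond the scatter), so this position can respond far more strongly than the earlier pair had shown. Among these compounds, compound 3 has no double bond outside aromatic rings, which shows that such a double bond, the one change separating compound 1 from compound 2, is not required for activity here, and the comparison with the saturated chain is an at least 280-fold lower number from compound 1 to compound 3 (2.45 log units; beyond the scatter). Compound 1 stands at a limit, so that last step gives a bound and not an exact size: the limit of > 10000 nM in this assay, at which 1 of the 3 values shown sits.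

The compounds shown leave open how much the two defined stereocentres contribute, since only one arrangement of the three-membered ring appears among them, and the numbers do not say why this group reads so differently from 2-(pyridin-3-yl)ethenyl. They also leave open how a four-membered carbon ring, a longer chain, or an amine on the pyridine ring would read at this carbonyl carbon.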